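This account rests on a few compounds, and the source may have more. Where it says the series, first, only, none or still open, it means among the compounds named here.

Working notes on the series. The shared core is seen in compound 1 `O=C(CSc1nnc(-c2ccncc2)o1)N/N=C/c1ccc(O)cc1`, which carries 4-hydroxyphenyl on the carbon with a double bond to nitrogen; in a functional assay on BGC-823 cells (Homo sapiens) for cytotoxicity, read by MTT assay, with a stated time of 48 h (a higher number here means a weaker inhibitor, a lower number a stronger inhibitor), compound 1 gives 7940 nM. Compound 2 `O=C(CSc1nnc(-c2ccncc2)o1)N/N=C/c1cc(Cl)cc(Cl)c1O` carries 3,5-dichloro-2-hydroxyphenyl at the same place, and in this assay compound 2 gives 6340 nM. The step of a 1.3-fold lower number from compound 1 to compound 2 (0.10 log units; within the scatter) stays inside the scatter. Of the two numbers shown, that of compound 2 is the smaller, yet the gap to compound 1 is within the scatter, so no order between the two can be read.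

Compound 3 `O=C(CSc1nnc(-c2ccncc2)o1)N/N=C/c1ccc(O)c(O)c1` differs from compound 2 in one place: 3,4-dihydroxyphenyl in place of 3,5-dichloro-2-hydroxyphenyl on a carbon with a double bond to nitrogen. For the measured compounds named here, no measured step swaps a dichloro-hydroxyphenyl for a dihydroxyphenyl. Going by the values given here, the one step in hand, between compound 1 and compound 2, moved the number only within the scatter, and compound 1 already holds a hydroxyphenyl at this carbon. The expectation for compound 3 in this assay is accordingly no shift beyond the scatter, an estimated step of a 1.1-fold higher number from compound 2 to compound 3 (0.04 log units; within the scatter). Compound 3 is estimated at 7000 nM, with a range from 3000 nM to 16000 nM.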

Compound 3, half-maximal inhibitory concentration: 1260 nM
Compound 3: middle estimate off by 5.6-fold (0.74 log units), on the high side; measured number below the stated range.
By their numbers in this assay, from the lowest: compound 3; then compounds 2 and 1 (each within the scatter of the next).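

On the carbon with a double bond to nitrogen, the aryl group can move the number in this assay beyond the scatter, something the step between the two earlier compounds did not show: 3,4-dihydroxyphenyl in place of 3,5-dichloro-2-hydroxyphenyl gives a 5.0-fold lower number from compound 2 to compound 3 (0.70 log units; beyond the scatter) in this series. The tighter comparison is hydroxy in place of hydrogen on an aromatic carbon, which gives a 6.3-fold lower number from compound 1 to compound 3 (0.80 log units; beyond the scatter) and so ties the change to one added hydroxy on the 4-hydroxyphenyl of compound 1. No measurement is at hand that would explain this shift, so it stands as an observation only.

Going by these compounds, whether the lower number of compound 3 survives with methoxy or an amine in place of the added hydroxy stays open, as does the behaviour of 3-hydroxyphenyl on its own at this carbon. On these data alone, all three compounds share the rest of the core, so it also remains open whether the same change gives a step of this kind with another group in place of the thioether chain or on other cell lines.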